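The compounds below may be only part of what the source reports. "The series", "measured", "known", "first", "only" and "open" are said of these compounds alone.

Values in a functional assay on MDA-MB-435 cells (Homo sapiens) for cytotoxicity, read by MTT assay, with a stated time of 72 h (a higher number here means a weaker inhibitor, a lower number a stronger inhibitor), are these:

Compound 1 `Nc1cccc(Nc2c(C(=O)NCc3ccc(F)cc3)nc(Br)c3cccnc23)c1` gives 8000 nM
Compound 2 `N[C@H]1CC[C@H](Nc2c(C(=O)NCc3ccc(F)cc3)nc(Br)c3cccnc23)CC1` gives 6000 nM
Compound 3 `O=C(NCc1ccc(F)cc1)c1nc(Br)c2cccnc2c1NCc1ccccc1` gives > 20000 nM

For compound 3 the value > 20000 nM is a limit and not a number. Compound 4 `COC(=O)CNc1c(C(=O)NCc2ccc(F)cc2)nc(Br)c2cccnc12` differs from compound 3 in one place, with methoxycarbonyl in place of phenyl on a saturated chain carbon bound to a nitrogen on an aromatic ring and the shared core unchanged. Within the data shown here, no measured step makes this change. The closest ones act on the same nitrogen: an at least 2.5-fold higher number from compound 1 to compound 3 (0.39 log units; beyond the scatter) for benzyl in place of 3-aminophenyl, an at least 3.3-fold higher number from compound 2 to compound 3 (0.52 log units; beyond the scatter) for benzyl in place of 4-aminocyclohexyl, and a 1.3-fold lower number from compound 1 to compound 2 (0.12 log units; within the scatter) for 4-aminocyclohexyl in place of 3-aminophenyl. Compound 4 carries neither of those two groups, so it is expected to stay near compound 3, with no step beyond the scatter in this assay and quite possibly another limit. The estimated step is a number no higher from compound 3 to compound 4 (the limit leaves the size open) and no larger. The estimate for compound 4 is 20000 nM with 8000 nM to 50000 nM as its expected range.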

Compound 4, half-maximal inhibitory concentration: 10000 nM
The estimate for compound 4 lay 2.0-fold (0.30 log units) above the measured number; the measured number falls inside the stated range.
By their numbers in this assay, from the lowest: compounds 2, 1 and 4 (each within the scatter of the next). At a limit, above all of these: compound 3.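

With (methoxycarbonyl)methyl on this nitrogen the result is a number rather than a limit, with an at least 2.0-fold lower number from compound 3 to compound 4 (0.30 log units; that floor lies within the scatter). The same group also gives a 1.7-fold higher number from compound 2 to compound 4 (0.22 log units; within the scatter) and a 1.3-fold higher number from compound 1 to compound 4 (0.10 log units; within the scatter), which shows that neither 3-aminophenyl nor 4-aminocyclohexyl is needed for a value in this range. Compound 3 alone remains a limit and not a number: the limit of > 20000 nM in this assay, at which 1 of the 4 values shown sits.

On these data alone, it remains open whether methoxycarbonyl itself contributes or whether removing phenyl is enough. A carboxylic acid, a primary amide or a plain ethyl group in the same place would separate these two readings.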